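Benzyl on the phenolic oxygen of a dihydrobenzofuran chalcone

This account rests on a few compounds, and the source may have more. Where it says the series, first, only, none or still open, it means among the compounds named here.

Compound 1 `CC1(C)Cc2c(OCc3ccccc3)ccc(C(=O)/C=C/c3ccc(Cl)cc3)c2O1`: > 100000 nM
Compound 2 `COc1ccc(/C=C/C(=O)c2ccc(O)c3c2OC(C)(C)C3)cc1`: 48400 nM

Going by the values given here, in a functional assay on PC-3 cells (Homo sapiens) for antiproliferative activity, read by MTT assay, with a stated time of 48 h (a lower number here means a stronger inhibitor, a higher number a weaker inhibitor), compound 2 gives 48400 nM, the only number among the results so far. Compound 1 reaches only a limit of the assay, > 100000 nM, and no number. Compound 3 `COc1ccc(/C=C/C(=O)c2ccc(OCc3ccccc3)c3c2OC(C)(C)C3)cc1` follows from compound 2 by benzyl in place of hydrogen on an oxygen on an aromatic ring. Among the compounds with values here, no step between measured compounds is recorded, so the size of this change rests on expectation. Compound 3 is expected to be the weaker inhibitor, with a step of a 2.1-fold higher number from compound 2 to compound 3 (0.32 log units; beyond the scatter) beyond the scatter, since compound 1, which also carries a benzyl on that oxygen, sits at the limit of > 100000 nM in this assay, at which 1 of the 2 values shown sits. Compound 3 is thus estimated at 100000 nM, between 40000 nM and 300000 nM.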

Compound 3, half-maximal inhibitory concentration: 13500 nM
Beside the measured number, compound 3's estimate is 7.4-fold (0.87 log units) above it; the whole stated range lies above it.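

In this assay, hydroxy to benzyloxy on this oxygen gives a 3.6-fold lower number from compound 2 to compound 3 (0.55 log units; beyond the scatter), so here the benzyl goes with a stronger inhibitor, not a weaker one. With the benzyl held in place, methoxy in place of chloro on an aromatic carbon gives an at least 7.4-fold lower number from compound 1 to compound 3 (0.86 log units; beyond the scatter). Compound 1 stands at a limit and not at a number: the limit of > 100000 nM in this assay, at which 1 of the 3 values shown sits. As far as these compounds go, whether the benzyl step holds with chloro in place of methoxy stays open. So does the outcome for other groups on this oxygen, such as a plain methyl or a chain ending in an amine.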